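The source may report more compounds than this note shows. Statements on the series, on what has been measured and on what is new or still open speak of the compounds shown alone.

Measured so far in a functional assay on the whole organism with Mus musculus as the target; on this read-out lower numbers stand for lower potency and higher numbers for higher potency (the scale is a negative logarithm):
compound 1 `CN1CCC(OC(=O)c2ccccc2F)CC1` gives 1.41
compound 2 `CN1CCC(OC(=O)c2ccc(Cl)c(Cl)c2)CC1` gives 1.08
compound 3 `Cc1ccc(C(=O)OC2CCN(C)CC2)cc1` gives 1.17

The three compounds share a core and differ only in the substitution of the aromatic ring of the ester. Compound 1 holds the highest of the three numbers. Compound 3 stands nearest to it, and the gap between the two lies within the usual scatter, so no order between compound 1 and compound 3 can be stated. Compound 2 stands furthest from compound 1, and that gap lies beyond the scatter, with compound 2 the lower of the pair.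

Compound 4 `CN1CCC(OC(=O)c2ccccc2C(F)(F)F)CC1` remains to be measured in this assay. It differs from compound 1 by trifluoromethyl in place of fluoro on an aromatic carbon, the trifluoromethyl entering ortho to a large group. Among the measured compounds shown here, no pair of measured compounds walks this same change, so the data give no step of known size to lean on. The expectation is a small step, most likely within the scatter and, if anything, slightly downward. For compound 4 the expected step is a number 0.11 log units lower from compound 1 to compound 4 (within the scatter). Compound 4 is therefore estimated at 1.3, within a range from 0.9 to 1.7.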

Compound 4, logarithm of the reciprocal of the active concentration, log(1/C): 1.49
Compound 4: middle estimate off by 0.19 log units, on the low side; the measured number falls inside the stated range.
By their numbers in this assay, from the lowest: compounds 2, 3, 1 and 4 (each within the scatter of the next, the first and the last beyond it).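

In this assay, among the compounds shown here, trifluoromethyl in place of fluoro on an aromatic carbon, ortho to a large group, gives a number 0.08 log units higher from compound 1 to compound 4 (within the scatter), the first step between compounds that differ in one place. At this position, a group of 4 heavy atoms thus takes the place of a group of 1 heavy atom with no difference that can be separated from the scatter. No measured property of either group accompanies this result.

On these data alone, whether an amine, a carboxylic acid or a methoxy group at this position would stay within the scatter of compound 1 remains open. As far as these compounds go, with a single pair walking this change, it is also open whether the same swap gives a step of similar size elsewhere on the aromatic ring.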